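This account rests on a few compounds, and the source may have more. Where it says the series, first, only, none or still open, it means among the compounds named here.

In a functional assay on MCF7 cells (Homo sapiens) for antiproliferative activity, read by MTT assay, with a stated time of 72 h (on this read-out lower numbers stand for stronger inhibition and higher numbers for weaker inhibition), compound 3 `COc1cc(-n2cnc3ccc(-c4ccc(C)cc4F)cc32)cc(OC)c1OC` gives 56 nM, the lowest number among the three measured compounds. Compound 1 `CCOc1ccc(-c2ccc3ncn(-c4cc(OC)c(OC)c(OC)c4)c3c2)cc1` gives 1710 nM. Compound 2 `COc1cc(-n2cnc3ccc(-c4ccccc4Cl)cc32)cc(OC)c1OC` gives > 10000 nM, which is a limit and not a number. The three compounds share one core and differ only in the aryl group on an aromatic carbon. Changing that group alone produces large steps: a 31-fold lower number from compound 1 to compound 3 (1.48 log units; beyond the scatter), an at least 170-fold lower number from compound 2 to compound 3 (2.25 log units; beyond the scatter) and an at least 5.8-fold higher number from compound 1 to compound 2 (0.76 log units; beyond the scatter).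

Compound 4 `COc1ccc(-c2ccc3ncn(-c4cc(OC)c(OC)c(OC)c4)c3c2)cc1F` changes the same place: 3-fluoro-4-methoxyphenyl in place of 2-fluoro-4-methylphenyl on an aromatic carbon, with 3-fluoro-4-methoxyphenyl in place of 2-fluoro-4-methylphenyl. Within the data shown here, the closest guide is a 31-fold lower number from compound 1 to compound 3 (1.48 log units; beyond the scatter), the only measured step that links an alkoxy-bearing aryl group to the group of compound 3. Compound 4 keeps a fluorine, as compound 3 does, but also carries an alkoxy group, as compound 1 does at 1710 nM. Three compounds support no rule, so a moderate step towards weaker inhibition is expected in this assay, smaller than a 31-fold lower number from compound 1 to compound 3 (1.48 log units; beyond the scatter) but beyond the scatter. The expected change is a 5.0-fold higher number from compound 3 to compound 4 (0.70 log units; beyond the scatter). For compound 4 the estimated value is 280 nM, with an expected range of 50 nM to 2000 nM.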

Compound 4, half-maximal inhibitory concentration: 520 nM
Compound 4: middle estimate off by 1.9-fold (0.27 log units), on the low side; low and high end bracket the measured number.
By their numbers in this assay, from the lowest: compound 3; then compound 4; then compound 1. At a limit, above all of these: compound 2.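

In this assay, an alkoxy-bearing aryl group at this position does not fix the number near that of compound 1: 3-fluoro-4-methoxyphenyl in place of 4-ethoxyphenyl gives a 3.3-fold lower number from compound 1 to compound 4 (0.52 log units; beyond the scatter). A fluorine on the aryl group does not set the level by itself either, as the change from 2-fluoro-4-methylphenyl to 3-fluoro-4-methoxyphenyl gives a 9.3-fold higher number from compound 3 to compound 4 (0.97 log units; beyond the scatter), so two fluorine-bearing groups are separated by a step beyond the scatter. The value of compound 2 is a limit and not a number, so an at least 19-fold lower number from compound 2 to compound 4 (1.28 log units; beyond the scatter) gives only a bound on how far chlorine-bearing and fluorine-bearing aryl groups lie apart: the limit of > 10000 nM in this assay, at which 1 of the 4 values shown sits.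

Each pair of aryl groups shown differs in more than one feature, so it remains open how much of the place of compound 4 relative to compound 1 belongs to the fluorine and how much to the shorter alkoxy group. Also open, as far as these compounds go, is how an aryl group carrying an amine, a carboxylic acid or a longer chain such as butoxy would read in this assay.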